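Working notes: 3-hydroxyazepan-1-yl to 6-hydroxy-1,4-oxazepan-4-yl

The compounds below may be only part of what the source reports. "The series", "measured", "known", "first", "only" and "open" are said of these compounds alone.

Values measured in an ADME assay on HepG2 2.2.15 cells (Homo sapiens) for cytotoxicity, read by luminescence, with a stated time of 3 days (a higher number here means that more compound is tolerated, a lower number that less compound is tolerated), are as follows.
- compound 1 `O=C(Nc1ccc(F)c(Cl)c1)c1ccc(F)c(S(=O)(=O)N2C[C@H](O)CC[C@H](O)C2)c1` gives 25500 nM
- compound 2 `O=C(Nc1ccc(F)c(Cl)c1)c1ccc(F)c(S(=O)(=O)N2CCCCCC(O)C2)c1` gives 11000 nM
- compound 3 `O=C(Nc1ccc(F)c(Cl)c1)c1ccc(F)c(S(=O)(=O)N2CCCCC(O)C2)c1` gives 15000 nM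

Compound 3 stands within the scatter of both other compounds, as shown by a 1.4-fold higher number from compound 2 to compound 3 (0.13 log units; within the scatter) and by a 1.7-fold lower number from compound 1 to compound 3 (0.23 log units; within the scatter) in the series. Only a 2.3-fold lower number from compound 1 to compound 2 (0.37 log units; beyond the scatter) exceeds the scatter, and it is modest.

Compound 4 `O=C(Nc1ccc(F)c(Cl)c1)c1ccc(F)c(S(=O)(=O)N2CCOC[C@@H](O)C2)c1` brings the change 6-hydroxy-1,4-oxazepan-4-yl in place of 3-hydroxyazepan-1-yl on a sulfonyl sulfur with 6-hydroxy-1,4-oxazepan-4-yl in place of 3-hydroxyazepan-1-yl on a sulfonyl sulfur. Among the compounds with values here, no measured step makes this exact swap. Within the data shown here, the nearest precedent for added oxygen is a 1.7-fold lower number from compound 1 to compound 3 (0.23 log units; within the scatter) read in reverse, so little movement is expected in this assay and any movement should be towards a higher number. The expected size is a 1.3-fold higher number from compound 3 to compound 4 (0.12 log units; within the scatter) and stays within the scatter. Compound 4 is estimated at 20000 nM (expected range 10000 nM to 42000 nM).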

Compound 4, half-maximal cytotoxic concentration: 14000 nM
Estimate against measurement, compound 4: 1.4-fold (0.15 log units) above, within the range that was stated.
By their numbers in this assay, from the lowest: compounds 2, 4, 3 and 1 (each within the scatter of the next, the first and the last beyond it).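

In this assay the second ring hetero atom of 6-hydroxy-1,4-oxazepan-4-yl, on a sulfonyl sulfur, leaves the number within the scatter of the 3-hydroxyazepan-1-yl parent (a 1.1-fold lower number from compound 3 to compound 4 (0.03 log units; within the scatter)). Compound 4 also stays within the scatter of both compounds that are separated beyond it (a 1.3-fold higher number from compound 2 to compound 4 (0.10 log units; within the scatter); a 1.8-fold lower number from compound 1 to compound 4 (0.26 log units; within the scatter)), so this change does not distinguish it from any other compound in the series. Nothing available explains this result. From the compounds shown here alone, whether an amine or a carboxylic acid on the seven-membered ring would give a step beyond the scatter remains open, as does the effect of the opposite configuration at the defined stereocentre.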